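A few compounds are considered here, and "the series" means these few. Any claim that something is new, unique, unknown or untested is made for them only; others in the source may bear on it.

Measured in a functional assay on HepG2 cells (Homo sapiens) for cytotoxicity, read by sulforhodamine B assay, with a stated time of 24 h; on this read-out higher numbers stand for weaker inhibition and lower numbers for stronger inhibition:
- Compound 1 `O=C1Nc2ccc(S(=O)(=O)N3CCOCC3)cc2/C1=N/c1ccc(Br)cc1` gives 11900 nM
- Compound 2 `N/N=C1\C(=O)Nc2ccc(S(=O)(=O)N3CCOCC3)cc21` gives 32400 nM

Compound 2 holds the higher of these two numbers, which makes it the weaker inhibitor of the pair. The next compound to consider is compound 3 `O=C1Nc2ccc(S(=O)(=O)N3CCOCC3)cc2/C1=N/c1ccc(C(=O)O)cc1`. It differs from compound 2 by 4-carboxyphenyl in place of amino on a double-bonded nitrogen.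

For the measured compounds named here, only one measured step bears on this change: a 2.7-fold higher number from compound 1 to compound 2 (0.43 log units; beyond the scatter). That modest step replaced 4-bromophenyl with amino at the same place. The change to compound 3 runs the other way, restoring a substituted phenyl, so a modest fall in the number is expected in this assay. Going by the values given here, no measured compound carries 4-carboxyphenyl, which keeps the expectation loose. The expected step is a 2.0-fold lower number from compound 2 to compound 3 (0.31 log units; beyond the scatter). For compound 3 the estimated value is 16000 nM, with an expected range of 6000 nM to 45000 nM.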

Compound 3, half-maximal inhibitory concentration: 23100 nM
Beside the measured number, compound 3's estimate is 1.4-fold (0.16 log units) below it; low and high end bracket the measured number.
By their numbers in this assay, from the lowest: compounds 1, 3 and 2 (each within the scatter of the next, the first and the last beyond it).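

In this assay, 4-carboxyphenyl in place of amino on the double-bonded nitrogen gives a 1.4-fold lower number from compound 2 to compound 3 (0.15 log units; within the scatter) and carboxy in place of bromo on the aromatic carbon gives a 1.9-fold higher number from compound 1 to compound 3 (0.29 log units; within the scatter), so compound 3 cannot be told apart from either neighbour. The earlier step, a 2.7-fold higher number from compound 1 to compound 2 (0.43 log units; beyond the scatter), is beyond the scatter, yet compound 3 now fills that gap, which means these values cannot show whether the phenyl ring or the bromo group accounts for it. Nothing measured here explains these results.

Still open, going by these compounds, is how a plain phenyl group, or a methoxy group or an amine in place of the bromo, would read in this assay. A longer alkyl chain on the double-bonded nitrogen would test whether an aromatic ring is needed there at all.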